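Shortening the chain on compound 2

The source may hold more compounds than are shown below. What is called first, only, known or untested is meant among the compounds shown, and "the series" means these compounds.

Values so far in a functional assay on MCF7 cells (Homo sapiens) for inhibition, read by fluorescence, with a stated time of 72 h (a higher number here means a weaker inhibitor of growth, a lower number a stronger inhibitor of growth), are these:
- Compound 1 `CCCCn1cnc2c(NCc3cccc(Cl)c3)nc(N[C@H]3CC[C@H](N)CC3)nc21` gives 2200 nM
- Compound 2 `CCCCCCn1cnc2c(Nc3cccc(Cl)c3)nc(N[C@H]3CC[C@H](N)CC3)nc21` gives 2700 nM

Only these two numbers exist so far, and compound 2 at 2700 nM lies within the usual scatter of compound 1 at 2200 nM, so no order can be read between them. The two compounds differ in more than one place. Among the compounds with values here, the series therefore offers no measured step for a single change.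

Compound 3 `CCCCn1cnc2c(Nc3cccc(Cl)c3)nc(N[C@H]3CC[C@H](N)CC3)nc21` has not yet been measured in this assay. It differs from compound 2 in one place: hydrogen in place of ethyl on a saturated chain carbon, four bonds along the chain from an aromatic nitrogen, which is hydrogen in place of ethyl on a saturated chain carbon, four bonds along the chain from an aromatic nitrogen.

Within the data shown here, the data hold no direct precedent for this change, so only a small shift is expected, with little confidence in its direction. The expected move is a 1.4-fold lower number from compound 2 to compound 3 (0.13 log units; within the scatter), which is no shift beyond the scatter. For compound 3 the estimated value is 2000 nM, with an expected range from 700 nM to 5500 nM as the likely span.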

Compound 3, concentration for 50% growth inhibition: 2000 nM
Estimate against measurement, compound 3: no gap at the digits printed; measured number inside the range.
By their numbers in this assay, from the lowest: compounds 3, 1 and 2 (each within the scatter of the next).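

With compound 3, the series gains its first single-change steps in this assay and both stay within the scatter. Hydrogen in place of ethyl on a saturated chain carbon, four bonds along the chain from an aromatic nitrogen, gives a 1.4-fold lower number from compound 2 to compound 3 (0.13 log units; within the scatter) and so does not separate the two chain lengths, while 3-chlorophenyl in place of 3-chlorobenzyl on a nitrogen on an aromatic ring gives a 1.1-fold lower number from compound 1 to compound 3 (0.04 log units; within the scatter) and leaves those two groups equally unseparated. Within the data shown here, neither step comes with any measurement that could explain it, so the notes record only that both changes leave the number inside the scatter of the series.

Still open, going by these compounds, is whether any change at the chain position moves the number beyond the scatter, for example a methyl or ethyl chain, a longer chain such as octyl, or an amine or a carboxylic acid at the chain end. The same question stands on the nitrogen on the aromatic ring, where a 2-phenylethyl group or a pyridyl ring in place of 3-chlorophenyl would test whether that position is as flat as these two values suggest.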